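Changing the group on the aromatic nitrogen

The compounds below may be only part of what the source reports. "The series", "measured", "known", "first", "only" and "open" are said of these compounds alone.

In a functional assay on MCF7 cells (Homo sapiens) for inhibition, read by sulforhodamine B assay, with a stated time of 48 h, tested at 50 uM (a lower number here means less inhibition of growth, a higher number more inhibition of growth at the concentration tested), compound 1 (`COc1ccc([C@@H]2C/C(=N/OCc3cn(-c4cccc(CO)c4)nn3)c3cc(CC=C(C)C)c(OC)cc3O2)cc1`) gives 42% and compound 2 (`COc1ccc([C@@H]2C/C(=N/OCc3cn(-c4cc(OC)c(OC)c(OC)c4)nn3)c3cc(CC=C(C)C)c(OC)cc3O2)cc1`) gives 45%. Within the data shown here, these two numbers lie within the scatter of each other, so they set no order, and compound 2 stands level with the only other measured compound.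

The next compound, compound 3 (`COc1ccc([C@@H]2C/C(=N/OCc3cn(-c4ccc(C(N)=O)cc4)nn3)c3cc(CC=C(C)C)c(OC)cc3O2)cc1`), differs from compound 2 at one place: 4-carbamoylphenyl in place of 3,4,5-trimethoxyphenyl on an aromatic nitrogen. In words, this is 4-carbamoylphenyl in place of 3,4,5-trimethoxyphenyl on an aromatic nitrogen, and the rest of the structure stays the same.

Among the measured compounds shown here, one measured step bears on this change, as it falls at the same place: a number 3 percentage points higher from compound 1 to compound 2 (within the scatter), with 3,4,5-trimethoxyphenyl in place of 3-(hydroxymethyl)phenyl. For the measured compounds named here, no measured compound carries 4-carbamoylphenyl, so this single step is weak guidance and gives no direction. Going by the values given here, with only that small step as precedent, no change beyond the scatter is expected, and no direction is favoured.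

The estimated step in this assay is a number 3 percentage points lower from compound 2 to compound 3 (within the scatter), which is expected to stay inside the scatter.

Compound 3 is expected at 42%, with an estimated range of 28% to 56%.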

Compound 3, percent growth inhibition at one concentration: 100%
For compound 3 the middle estimate is 58 percentage points below the measured one; measured number above the stated range.
By their numbers in this assay, from the lowest: compounds 1 and 2 (each within the scatter of the next); then compound 3.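

In this assay the group on the aromatic nitrogen of the five-membered ring proves able to change the read-out strongly, which the earlier pair, level within the scatter, gave no sign of. With 4-carbamoylphenyl entering, the result is a number 55 percentage points higher from compound 2 to compound 3 (beyond the scatter) and, against the other aryl group, a number 58 percentage points higher from compound 1 to compound 3 (beyond the scatter) in the same assay, so the gain holds against both 3,4,5-trimethoxyphenyl and 3-(hydroxymethyl)phenyl, which stand level with each other. No measured information on these compounds accounts for this jump.

Going by these compounds, with a single compound carrying the carbamoyl group, it remains open whether the gain depends on that group itself or on the whole 4-carbamoylphenyl unit, and a carboxylic acid or a nitrile in its place, or an unsubstituted phenyl ring, would help to separate these readings. In this assay compound 3 gives 100% at the one concentration tested, so the data shown do not tell how far its effect would persist at lower concentrations, or whether it would carry over to other cell lines.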